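A second fluoro on compound 2

A few compounds are considered here, and "the series" means these few. Any claim that something is new, unique, unknown or untested is made for them only; others in the source may bear on it.

In an ADME assay on 2209-23 cells (Homo sapiens) for cytotoxicity, read by WST assay and thymidine incorporation (a lower number here means that less compound is tolerated, a higher number that more compound is tolerated), compound 2 `CC(C)(C)[C@H]1C(O)=C(C2=CS(=O)(=O)c3cc(NS(C)(=O)=O)ccc3N2)C(=O)N1Cc1ccc(F)cc1` gives > 50000 nM, which is a limit and not a number. Compound 1 `CC(C)(C)CCN1C(=O)C(C2=CS(=O)(=O)c3cc(NS(C)(=O)=O)ccc3N2)=C(O)[C@@H]1C(C)(C)C` gives > 50000 nM, also a limit. Compound 3 `CC(C)(C)[C@H]1C(O)=C(C2=C(Cl)S(=O)(=O)c3cc(NS(C)(=O)=O)ccc3N2)C(=O)N1Cc1ccc(F)cc1` gives > 50000 nM, again a limit.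

Compound 4 `CC(C)(C)[C@H]1C(O)=C(C2=CS(=O)(=O)c3cc(NS(C)(=O)=O)ccc3N2)C(=O)N1Cc1ccc(F)cc1F` turns the 4-fluorobenzyl of compound 2 into 2,4-difluorobenzyl: fluoro in place of hydrogen on an aromatic carbon. For the measured compounds named here, two measured steps bear on this: a step that the two limits leave unreadable from compound 1 to compound 2, which introduced the 4-fluorophenyl group, and a step that the two limits leave unreadable from compound 2 to compound 3, which added a chloro. Neither size can be read because of the limit of > 50000 nM in this assay, at which 3 of the 3 values shown sit. They therefore point in no direction, and nothing beyond the usual scatter is expected. The expected step is a step that the limit leaves unreadable from compound 2 to compound 4. Compound 4 is estimated at 60000 nM, with an expected range from 30000 nM to 120000 nM.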

Compound 4, half-maximal cytotoxic concentration: > 50000 nM
Compound 4: a limit, no number; the forecaster's own chance of this, stated with the estimate: 85%; the middle value lies beyond the limit too.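

Compound 4, like compound 1 and compound 2, gives only a limit in this assay, so neither new step can be read: the limit of > 50000 nM in this assay, at which 4 of the 4 values shown sit.

The compounds shown leave open how much of any of them is tolerated, and whether the second fluoro changes that.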